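Adding a Hydroxy Group to Compound 2

The compounds below may be only part of what the source reports. "The series", "measured", "known", "first", "only" and "open" are said of these compounds alone.

Of the compounds shown here, three have so far been measured in a functional assay (Female gonad) for cytotoxicity, with Homo sapiens as the target; on this read-out higher numbers stand for weaker inhibition and lower numbers for stronger inhibition. Compound 1 `O=[N+]([O-])c1ccc(NN=C(c2ccccc2O)c2ccccc2O)c([N+](=O)[O-])c1` gives 5 ug/mL. Compound 3 `C/C(=N\Nc1ccc([N+](=O)[O-])cc1)c1ccc(O)cc1` gives 6 ug/mL. Compound 2 `O=[N+]([O-])c1ccc(NN=C(c2ccccc2)c2ccccc2)c([N+](=O)[O-])c1` is reported only as a limit of the assay, > 10 ug/mL, and not as a number. On the numbers shown, compound 2 therefore stands at the limit of > 10 ug/mL in this assay, at which 1 of the 3 values shown sits. Compound 1 and compound 3, by contrast, sit at values that lie within the usual scatter of each other, so no order between them can be claimed.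

Compound 4 `O=[N+]([O-])c1ccc(N/N=C(\c2ccccc2)c2ccc(O)cc2)c([N+](=O)[O-])c1` has not yet been measured. It differs from compound 2 in a single place: hydroxy in place of hydrogen on an aromatic carbon. Among the measured compounds shown here, no pair of measured compounds traces this exact change, so the size of the step can only be judged indirectly. Compound 1 and compound 3 both carry a hydroxy group and both give a number rather than a limit. Compound 2 carries none and gives only a limit.

For compound 4 the expected step is an at least 1.6-fold lower number from compound 2 to compound 4 (0.22 log units; that floor lies within the scatter), towards stronger inhibition rather than no change beyond the scatter. Compound 4 is thus estimated at 6 ug/mL, with a likely range from 3 ug/mL to 12 ug/mL.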

Compound 4, half-maximal inhibitory concentration: 0.3 ug/mL
Compound 4: the middle estimate sits 20-fold (1.30 log units) above what was measured, and the stated range ends above it.
By their numbers in this assay, from the lowest: compound 4; then compounds 1 and 3 (each within the scatter of the next). At a limit, above all of these: compound 2.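

This change, hydroxy in place of hydrogen on an aromatic carbon, para to a large group, gives a large step in this assay, well beyond the scatter: an at least 33-fold lower number from compound 2 to compound 4 (1.52 log units; beyond the scatter). The earlier compounds shown here that carry a hydroxy group differ from compound 2 in more than one place, so they could not separate this change from the others, whereas this pair shows that a single hydroxy group at this one place is enough to produce the step. The size of the step is a floor and not an exact figure, because compound 2 stands at a limit: the limit of > 10 ug/mL in this assay, at which 1 of the 4 values shown sits.

What an amine, a methoxy group or a carboxylic acid would give at this same place remains open, so the compounds shown cannot tell whether the step is specific to hydroxy. Also open, going by these compounds, is whether hydroxy on a different aromatic carbon of the shared core would give a step of similar size, and whether this step would hold in any read-out other than this assay.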